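A few compounds are considered here, and "the series" means these few. Any claim that something is new, unique, unknown or untested is made for them only; others in the source may bear on it.

Of the compounds shown here, two have so far been measured in a functional assay on isolated protein with Glucose-dependent insulinotropic receptor (Mus musculus) as the target, read by HTRF and cAMP accumulation, with a stated time of 45 min; a higher number here means a larger maximal response, a lower number a smaller maximal response. Compound 1, `CC(C)(C)OC(=O)N1CCN(c2ncc(OCc3ccc(S(C)(=O)=O)cc3)nn2)CC1`, gives 103% in this assay, a response matching the reference agonist. Compound 2, `C[C@@H]1CN(c2ncc(OCc3ccc(S(C)(=O)=O)cc3)cn2)CCN1C(=O)OC(C)(C)C`, gives 16% in this assay. Going by the values given here, compound 2 therefore stands at the lower of the two numbers, and the only other measured compound, compound 1, lies above it by a gap that is well beyond the usual scatter of this measurement. The two compounds differ in several places at once, so those two values alone say nothing about any single change.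

Compound 3, `C[C@H]1CN(c2ncc(OCc3ccc(S(C)(=O)=O)cc3)cn2)CCN1C(=O)OC(C)(C)C`, is the next compound to be measured. Compared with compound 2 it differs as follows: the two compounds have the same atoms and bonds and differ only in configuration as drawn: 1 of 1 stereo elements differ; a stereocentre at a saturated ring carbon is drawn R in compound 2 and S in compound 3. Among the compounds with values here, no step between two measured compounds that differ in one place is available, so the size of this change cannot be calibrated from the present data. Because compound 2 sits at 16%, there is far more room upward than downward, and mirror-image pairs often differ greatly in this kind of response. Compound 3 is therefore expected to reach about 55%, within an estimated range from 10% to 105%. This estimate corresponds to an expected step of a number 39 percentage points higher from compound 2 to compound 3 (beyond the scatter), upward and beyond the scatter, though a step within the scatter cannot be ruled out.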

Compound 3, intrinsic activity: the largest response reached, in percent of the reference agonist's: 45%
Estimate against measurement, compound 3: 10 percentage points above; the range from low to high includes it.
By their numbers in this assay, from the lowest: compound 2; then compound 3; then compound 1.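

In this assay, inverting the one stereocentre at a saturated ring carbon gives a number 29 percentage points higher from compound 2 to compound 3 (beyond the scatter). Going by these compounds alone, this is the first change that can be read on its own, and it shows that the maximal response depends on the spatial arrangement at this position, even though no atom is added or removed, with the S form giving the larger response of this pair. The step can be assigned to that stereocentre alone, because nothing else separates the two structures: the fact that compounds 2 and 3 differ only in the configuration as drawn

Within the data shown here, this single mirror-image pair shows that configuration at this carbon matters, but not why it matters, nor whether a step of this size would recur on a different core, such as the one carried by compound 1. It also leaves open how the response would change if an ethyl or hydroxymethyl group stood at this saturated ring carbon, or if the tert-butyl carbamate on the same ring were replaced by a simple amide, and whether the configuration would still have the same influence in those cases.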